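A few compounds are considered here, and "the series" means these few. Any claim that something is new, unique, unknown or untested is made for them only; others in the source may bear on it.

Compound 1 `CCOC(=O)c1cccc(-c2ccc(OCC)cc2)c1` is the reference point of this small set. In an assay on COS-7 cells for inhibition of patatin-like phospholipase domain-containing protein 2 (Mus musculus), tested at 200 uM (a higher number here means more inhibition at the concentration tested (going by the name of the read-out), a lower number less inhibition), compound 1 gives 87%, the highest of the three numbers seen so far. Compound 2 `CCOC(=O)c1cccc(-c2ccc(C(C)=O)cc2)c1` gives 36%, and compound 3 `CCOC(=O)c1cccc(-c2ccc(C(C)N(C)C)cc2)c1` gives 50%, so that a number 51 percentage points lower from compound 1 to compound 2 (beyond the scatter) and a number 37 percentage points lower from compound 1 to compound 3 (beyond the scatter), while a number 14 percentage points higher from compound 2 to compound 3 (beyond the scatter). The unmeasured compound 4 `CCOc1ccc(-c2cccc(C(=O)N3CCCC3)c2)cc1` differs from compound 1 at a different place: pyrrolidin-1-yl in place of ethoxy on a carbonyl carbon. None of the three measured steps touches the carbonyl carbon; all of them alter the ethoxy on an aromatic carbon, which compound 4 keeps intact. The measured steps therefore do not bear directly on this change, and they show only that the read-out in this assay can move by large amounts from a single replacement. Within the data shown here, with no guiding step at the carbonyl, a drop of modest size from compound 1 to compound 4, or none beyond the scatter, is expected, that is a number 17 percentage points lower from compound 1 to compound 4 (beyond the scatter). Compound 4 is accordingly estimated to give 70% in this assay, within a range from 40% to 95%.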

Compound 4, a percentage reported as inhibition, at one concentration (the size of the read-out at that concentration, not a potency): 53%
Compound 4: the middle estimate sits 17 percentage points above what was measured, and the stated range covers the measured number.
By their numbers in this assay, from the lowest: compound 2; then compounds 3 and 4 (each within the scatter of the next); then compound 1.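

Among these compounds, with the ethoxycarbonyl changed to (pyrrolidin-1-yl)carbonyl, this assay records a number 34 percentage points lower from compound 1 to compound 4 (beyond the scatter), so the read-out also responds to a replacement on the carbonyl carbon, a place the earlier steps left untouched. Compound 4 keeps the ethoxy on an aromatic carbon, which shows that this group alone does not hold the number at the level of compound 1. Nothing available explains why this replacement lowers the number.

The compounds shown leave open whether the drop follows from the nitrogen attached to the carbonyl carbon or from the five-membered ring, which dimethylamino or morpholin-4-yl at that place could help separate. They also leave open how methoxy, a longer alkoxy chain or a carboxylic acid would read there.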